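The source may report more compounds than this note shows. Statements on the series, on what has been measured and on what is new or still open speak of the compounds shown alone.

Compound 3 `COc1cc2oc(=O)n(CCC(=O)O)c2cc1Cl` carries a methyl on the oxygen on the aromatic ring of the shared core, and in an assay on HEK293 cells for inhibition of kynurenine 3-monooxygenase (Homo sapiens), read by LC-MS, with a stated time of 20 h (on this read-out lower numbers stand for stronger inhibition and higher numbers for weaker inhibition), compound 3 gives 5010 nM, the highest of the three numbers measured. Its two neighbours keep the core but carry a larger group at that oxygen: compound 1 `O=C(O)CCn1c(=O)oc2cc(OCC3CCC3)c(Cl)cc21` gives 1260 nM, and compound 2 `O=C(O)CCn1c(=O)oc2cc(OCc3ccccc3)c(Cl)cc21` gives 1580 nM. Replacing those groups by hydrogen raised the number, a 4.0-fold higher number from compound 1 to compound 3 (0.60 log units; beyond the scatter) and a 3.2-fold higher number from compound 2 to compound 3 (0.50 log units; beyond the scatter), whereas a 1.3-fold higher number from compound 1 to compound 2 (0.10 log units; within the scatter). Compound 4 `C[C@@H](Oc1cc2oc(=O)n(CCC(=O)O)c2cc1Cl)c1ncccn1` makes the reverse kind of move: a group of 8 heavy atoms (6 carbon, 2 nitrogen; one six-membered aromatic ring with 2 hetero atoms) in place of one carbon atom, on an oxygen on an aromatic ring. The measured steps that bear on it, read in reverse, both point to a modest lowering of the number. Compound 4 is therefore expected to give 1100 nM, within a range of 300 nM to 3500 nM, which would be a step of a 4.6-fold lower number from compound 3 to compound 4 (0.66 log units; beyond the scatter).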

Compound 4, half-maximal inhibitory concentration: 3160 nM
Compound 4: middle estimate off by 2.9-fold (0.46 log units), on the low side; low and high end bracket the measured number.
By their numbers in this assay, from the lowest: compounds 1, 2, 4 and 3 (each within the scatter of the next, the first and the last beyond it).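

At this oxygen on an aromatic ring, a larger group does not by itself separate a compound from the methyl: the group with a six-membered aromatic ring with 2 hetero atoms and a defined stereocentre stays within the scatter of it (a 1.6-fold lower number from compound 3 to compound 4 (0.20 log units; within the scatter)). That group is also level with the phenyl-bearing group (a 2.0-fold higher number from compound 2 to compound 4 (0.30 log units; within the scatter)) and stands apart only from the cyclobutyl-bearing one (a 2.5-fold higher number from compound 1 to compound 4 (0.40 log units; beyond the scatter)). No measured evidence explains this result. The compounds shown leave open what an amine or a longer chain at this oxygen would give.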